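This account rests on a few compounds, and the source may have more. Where it says the series, first, only, none or still open, it means among the compounds named here.

The measured compounds, all tested in a functional assay on A549 cells (Homo sapiens), read by MTT assay, with a stated time of 72 h; on this read-out higher numbers stand for weaker inhibition and lower numbers for stronger inhibition:

Compound 1, `O=c1[nH]cnc2c1c(-c1ccoc1)cn2[C@@H]1O[C@H](CO)[C@@H](O)[C@H]1O`, gives in this assay only a limit, > 20000 nM.
Compound 2, `O=c1[nH]cnc2c1c(-c1cc3ccccc3o1)cn2[C@@H]1O[C@H](CO)[C@@H](O)[C@H]1O`, gives in this assay only a limit, > 20000 nM.
Compound 3, `Nc1nc(N)c2c(-c3ccoc3)cn([C@@H]3O[C@H](CO)[C@@H](O)[C@H]3O)c2n1`, gives in this assay only a limit, > 20000 nM.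

Compound 1 and compound 2 share a core and differ by 1-benzofuran-2-yl in place of furan-3-yl on an aromatic carbon. The size of that step, a step that the two limits leave unreadable from compound 1 to compound 2, cannot be read from two limits. Compound 3 carries a different core; the difference between the two cores is not broken down here.

Compound 4, `Nc1nc(N)c2c(-c3cc4ccccc4o3)cn([C@@H]3O[C@H](CO)[C@@H](O)[C@H]3O)c2n1`, is not yet measured. It stands to compound 3 as compound 2 stands to compound 1, the same change at the same place: 1-benzofuran-2-yl in place of furan-3-yl on an aromatic carbon.

Compound 4 is expected to stay where the others sit, because the limit of > 20000 nM in this assay, at which 3 of the 3 values shown sit, gives no value that moves off the limit, and the expected step that the limit leaves unreadable from compound 3 to compound 4 is therefore taken as flat. The estimate for compound 4 in this assay is 25000 nM, with a range from 8000 nM to 80000 nM.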

Compound 4, half-maximal inhibitory concentration: > 20000 nM
Compound 4 ended at the assay's limit; the forecaster's own chance of this, stated with the estimate: 85%; the middle value lies beyond the limit too.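

Compound 3 and compound 4 each give only a limit in this assay, so no new step can be read from the change of furan-3-yl to 1-benzofuran-2-yl. The compounds shown leave open whether that change alters inhibition at all, and whether either core can inhibit these cells, as all values share one ceiling: the limit of > 20000 nM in this assay, at which 4 of the 4 values shown sit.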